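Replacing the side chain of compound 3

The compounds below may be only part of what the source reports. "The series", "measured", "known", "first", "only" and "open" are said of these compounds alone.

Within the data shown here, in an ADME assay on microsomes from liver (Homo sapiens) for metabolic stability, read by LC-MS, tested at 1 uM (a lower number here means slower removal, a higher number faster removal of the compound), compound 3 `NC(=O)C1CCN(Cc2ccc([C@H]3CC[C@]4(CC3)OOC3(O4)C4CC5CC(C4)CC3C5)cc2)CC1` gives 10 mL.min-1.g-1, the only actual number in this small series. Compound 1 `NCCCCCOc1ccc([C@H]2CC[C@]3(CC2)OOC2(O3)C3CC4CC(C3)CC2C4)cc1` reports a limit, < 7 mL.min-1.g-1. Compound 2 `NCCOc1ccc([C@H]2CC[C@]3(CC2)OOC2(O3)C3CC4CC(C3)CC2C4)cc1` also reports a limit, < 7 mL.min-1.g-1.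

Compound 4 `CC(C)(N)CCOc1ccc([C@H]2CC[C@]3(CC2)OOC2(O3)C3CC4CC(C3)CC2C4)cc1` changes compound 3 on an aromatic carbon, para to a large group, where 3-amino-3-methylbutoxy stands in place of (4-carbamoylpiperidin-1-yl)methyl: 3-amino-3-methylbutoxy in place of (4-carbamoylpiperidin-1-yl)methyl on an aromatic carbon. The entering group is an amine-bearing alkoxy chain, as are the (5-aminopentyl)oxy group of compound 1 and the 2-aminoethoxy group of compound 2.

Among the measured compounds shown here, two measured steps bear most directly on this change, since they make a similar replacement in the opposite direction: an at least 1.4-fold higher number from compound 1 to compound 3 (0.15 log units; that floor lies within the scatter) and an at least 1.4-fold higher number from compound 2 to compound 3 (0.15 log units; that floor lies within the scatter). Both are floors and not full sizes. The two amines themselves offer little further guidance, with a step that the two limits leave unreadable from compound 1 to compound 2.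

A lower number in this assay is therefore expected, and the reading may well fall at the limit of < 7 mL.min-1.g-1 in this assay, at which 2 of the 3 values shown sit. The expected change is a 1.7-fold lower number from compound 3 to compound 4 (0.22 log units; within the scatter), a small estimated step that stays within the scatter. For compound 4 the estimate is 6 mL.min-1.g-1, with an expected range from 3 mL.min-1.g-1 to 12 mL.min-1.g-1.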

Compound 4, intrinsic clearance in microsomes: < 7 mL.min-1.g-1
Compound 4: a limit, no number; the forecaster's own chance of this, stated with the estimate: 60%; the middle value is on the limit's open side.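

In this assay, putting 3-amino-3-methylbutoxy in place of (4-carbamoylpiperidin-1-yl)methyl on the aromatic carbon gives an at least 1.4-fold lower number from compound 3 to compound 4 (0.15 log units; that floor lies within the scatter). Compound 4 reports a limit and not a number, so a chain with branching at the amine-bearing carbon joins the straight (5-aminopentyl)oxy group of compound 1 and the 2-aminoethoxy group of compound 2, and none of the three amine-bearing alkoxy chains gives a measured number at this position. The steps among compound 1, compound 2 and compound 4 cannot be read, and chain length and branching therefore cannot be told apart, because all three sit at one limit: the limit of < 7 mL.min-1.g-1 in this assay, at which 3 of the 4 values shown sit.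

From the compounds shown here alone, how far these three chains lie under that limit stays open, and so does whether any real difference separates them from the group of compound 3, whose floor lies within the scatter. Going by these compounds, it is also open which part of the group of compound 3 goes with its measured number, a question that a piperidin-1-ylmethyl group without the carbamoyl, or a chain ending in a carboxylic acid in place of the amine, could begin to address.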